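Swapping fluoro for bromo on a weak inhibitor

A few compounds are considered here, and "the series" means these few. Any claim that something is new, unique, unknown or untested is made for them only; others in the source may bear on it.

Compound 1 `CCO[C@H]1C[C@@H](c2coc3ccc(F)cc3c2=O)N(c2ccccc2)O1`: > 60000 nM (a limit)
Compound 2 `O=c1c([C@@H]2C[C@H](c3ccccc3)ON2c2ccccc2)coc2ccc(F)cc12`: 60000 nM

Both results come from a functional assay on Caco-2 cells (Homo sapiens) for inhibition, read by sulforhodamine B assay, with a stated time of 48 h; a lower number here means a stronger inhibitor, a higher number a weaker inhibitor. The result for compound 1, > 60000 nM, is a limit and not a number. Among the measured compounds shown here, compound 2 gives 60000 nM, the only true number available, so it has no numerical neighbour to be ranked against.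

Compound 3 `O=c1c([C@@H]2C[C@H](c3ccccc3)ON2c2ccccc2)coc2ccc(Br)cc12` differs from compound 2 in one place: bromo in place of fluoro on an aromatic carbon. That is bromo in place of fluoro on an aromatic carbon.

For the measured compounds named here, the only measured step, a number no higher from compound 1 to compound 2 (the limit leaves the size open), is a change elsewhere in the molecule and its size stays open. Going by the values given here, no measured step exchanges one halogen for another, so the evidence here is thin. A small move towards stronger inhibition is expected, a 1.5-fold lower number from compound 2 to compound 3 (0.18 log units; within the scatter), and it may not clear the usual scatter. For compound 3 the estimated value in this assay is 40000 nM, with an expected range of 12000 nM to 75000 nM.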

Compound 3, half-maximal inhibitory concentration: > 60000 nM
Compound 3: a limit, no number; the forecaster's own chance of this, stated with the estimate: 35%; middle value at least 1.5-fold (0.17 log units) away from the limit.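

In this assay, compound 3 gives > 60000 nM, which is a limit and not a number. This is the first change shown on this aromatic carbon, and the halogen exchange brings no gain in inhibition: the result is a number no lower from compound 2 to compound 3 (the limit leaves the size open). The size of this step cannot be read, and the effect of bromo cannot be ranked more finely, because the results gather at one limit: the limit of > 60000 nM in this assay, at which 2 of the 3 values shown sit.

On these data alone, whether an amine, a carboxylic acid or a methoxy group on this aromatic carbon would give a lower number remains open. Also open, as far as these compounds go, is whether bromo in this position would behave the same way with ethoxy, as in compound 1, in place of the phenyl on the saturated ring carbon.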